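The compounds below may be only part of what the source reports. "The series", "measured", "known", "first", "only" and "open" are said of these compounds alone.

Measured compounds:
compound 1 `CC(C)CCn1cnc2c(Nc3ccccc3)nc(N[C@H]3CC[C@H](N)CC3)nc21` — 6400 nM
compound 2 `CCCCn1cnc2c(Nc3ccccc3)nc(N[C@H]3CC[C@H](N)CC3)nc21` — 4900 nM
compound 3 `N[C@H]1CC[C@H](Nc2nc(Nc3cccc(Cl)c3)c3ncn(Cc4ccccc4)c3n2)CC1` — 10200 nM

In a functional assay on BT-474 cells (Homo sapiens) for inhibition, read by fluorescence, with a stated time of 72 h (on this read-out lower numbers stand for stronger inhibition of growth and higher numbers for weaker inhibition of growth), compound 1 gives 6400 nM, the second highest of the three numbers. Compound 2 gives 4900 nM, and compound 3 gives 10200 nM; both of these lie within the scatter of compound 1, so the three measured compounds cannot be told apart on this read-out. Going by the values given here, the only step measured in one place, a 1.3-fold lower number from compound 1 to compound 2 (0.12 log units; within the scatter), concerns the chain on the core and is within the scatter. Compound 3 differs from compound 1 in two places at once, so its value shows only that a benzyl chain with a chloro on the anilino ring gives a number in the same band.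

Compound 4 `CC(C)CCn1cnc2c(Nc3ccc(O)cc3)nc(N[C@H]3CC[C@H](N)CC3)nc21` differs from compound 1 as follows: hydroxy in place of hydrogen on an aromatic carbon. Among the compounds with values here, no measured step bears on a change at the anilino ring; the chain step is remote from it and itself within the scatter. The expectation is therefore a step of a 1.4-fold lower number from compound 1 to compound 4 (0.15 log units; within the scatter) in this assay, not beyond the scatter in either direction. Compound 4 is estimated at 4500 nM, with a range from 1500 nM to 14000 nM.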

Compound 4, concentration for 50% growth inhibition: 7700 nM
The estimate for compound 4 lay 1.7-fold (0.23 log units) below the measured number, and the stated range covers the measured number.
By their numbers in this assay, from the lowest: compounds 2, 1, 4 and 3 (each within the scatter of the next, the first and the last beyond it).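

In this assay, the change from phenyl to 4-hydroxyphenyl gives a 1.2-fold higher number from compound 1 to compound 4 (0.08 log units; within the scatter). Going by these compounds alone, this is the first single-place step at the anilino ring, and it shows that a hydroxy on this aromatic carbon, para to a large group, leaves the number within the scatter, as the chain change in a 1.3-fold lower number from compound 1 to compound 2 (0.12 log units; within the scatter) also does. No evidence is available on why the hydroxy leaves the number there.

From the compounds shown here alone, it remains open whether a methoxy, an amine or a carboxylic acid on this same carbon would move the number beyond the scatter. Going by these compounds, it is also open whether the hydroxy would give a similar step on the butyl chain of compound 2.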